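The source may hold more compounds than are shown below. What is called first, only, known or untested is meant among the compounds shown, and "the series" means these compounds.

The measured compounds in an assay on isolated protein for inhibition of Polyunsaturated fatty acid 5-lipoxygenase (Homo sapiens), read by HPLC, with a stated time of 10 min; on this read-out higher numbers stand for weaker inhibition and lower numbers for stronger inhibition:
compound 1, `Cc1cc(NC(=O)Nc2ccccc2Cl)ccc1OCc1nc2ccccc2s1`, 680 nM;
compound 2, `O=C(Nc1ccccc1)Nc1ccc(OCc2nc3ccccc3s2)cc1`, 420 nM;
compound 3, `O=C(Nc1ccc(OCc2nc3ccccc3s2)cc1)Nc1ccc(Cl)c(Cl)c1`, 570 nM.

Compound 3 stands second highest of these three numbers, but its gaps to compound 1 and to compound 2 both lie within the scatter, so no order among the three can be read. Compound 4, `O=C(Nc1ccc(OCc2nc3ccccc3s2)cc1)Nc1ccccc1Cl`, differs from compound 3 in one place: 2-chlorophenyl in place of 3,4-dichlorophenyl on an amide-type nitrogen. For the measured compounds named here, only one measured step touches the same position, a 1.4-fold higher number from compound 2 to compound 3 (0.13 log units; within the scatter), and it stayed within the scatter. Compound 1 also carries a 2-chlorophenyl on an amide-type nitrogen, and its number sits close to that of compound 3. Compound 4 is therefore expected to shift by a 1.0-fold lower number from compound 3 to compound 4 (0.02 log units; within the scatter), which is no change beyond the scatter. Compound 4 is estimated at 550 nM, with a range from 280 nM to 1100 nM.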

Compound 4, half-maximal inhibitory concentration: 360 nM
Compound 4: the middle estimate sits 1.5-fold (0.18 log units) above what was measured; measured number inside the range.
By their numbers in this assay, from the lowest: compounds 4, 2, 3 and 1 (each within the scatter of the next).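

In this assay, exchanging the aryl group on the amide-type nitrogen moves the number only within the scatter (a 1.6-fold lower number from compound 3 to compound 4 (0.20 log units; within the scatter)), and the same holds for chloro in place of hydrogen on the aromatic carbon (a 1.2-fold lower number from compound 2 to compound 4 (0.07 log units; within the scatter)), so phenyl, 2-chlorophenyl and 3,4-dichlorophenyl cannot be told apart at this position. Hydrogen in place of methyl on an aromatic carbon also stays within the scatter (a 1.9-fold lower number from compound 1 to compound 4 (0.28 log units; within the scatter)). Nothing at hand offers a reason for these numbers. From the compounds shown here alone, whether an amine, a carboxylic acid or a longer chain in place of the chloro would move the number beyond the scatter remains open.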